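Carbamate in place of ethyl ether on a shared core

A few compounds are considered here, and "the series" means these few. Any claim that something is new, unique, unknown or untested is made for them only; others in the source may bear on it.

Measured compounds:
- compound 1, `CCOc1cc(=O)n(CCCO)c2c1CC(C/C=C(\C)CCC=C(C)C)C(C)(C)C2`: 67.8%
- compound 2, `COc1ccc(C(=O)NCCCOc2cc(=O)n(CCCO)c3c2CC(C/C=C(\C)CCC=C(C)C)C(C)(C)C3)cc1`: 45.7%

Both compounds were tested in a functional assay on PANC-1 cells (Homo sapiens) for inhibition, read by MTT assay, with a stated time of 24 h, tested at 10 uM; a higher number here means more inhibition at the concentration tested (going by the name of the read-out), a lower number less inhibition. Among the compounds with values here, compound 1 gives the higher of the two numbers, and its one neighbour, compound 2, lies a number 22.1 percentage points lower from compound 1 to compound 2 (beyond the scatter).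

Compound 3, `CC(C)=CCC/C(C)=C/CC1Cc2c(OC(=O)Nc3ccc(F)c(F)c3)cc(=O)n(CCCO)c2CC1(C)C`, is not yet measured. It differs from compound 1 in one place: (3,4-difluorophenyl)carbamoyl in place of ethyl on an oxygen on an aromatic ring. Cut one bond further out, the change reads ethoxy to ((3,4-difluorophenyl)carbamoyl)oxy.

Within the data shown here, no measured step touches this exact position. Among the measured compounds shown here, the only step known, a number 22.1 percentage points lower from compound 1 to compound 2 (beyond the scatter), also adds an aromatic amide-like group to compound 1, though elsewhere, and the number fell modestly. Taking that as a loose guide, a modest fall is expected for compound 3, a number 17.8 percentage points lower from compound 1 to compound 3 (beyond the scatter), with wide uncertainty. The estimate for compound 3 is 50%, within a range from 30% to 70%.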

Compound 3, a percentage reported as inhibition, at one concentration (the size of the read-out at that concentration, not a potency): 43.7%
The estimate for compound 3 lay 6.3 percentage points above the measured number; low and high end bracket the measured number.
By their numbers in this assay, from the lowest: compounds 3 and 2 (each within the scatter of the next); then compound 1.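

Swapping the small ethyl on the oxygen on the aromatic ring for (3,4-difluorophenyl)carbamoyl gives the first reading at this position: in this assay there is a number 24.1 percentage points lower from compound 1 to compound 3 (beyond the scatter), so this much larger group lowers the inhibition but does not abolish it, with compound 3 still at 43.7%. Together with the earlier step, this means both changes made to compound 1, at two different places and each bringing in an aromatic ring, lower the number. Nothing available here bears on the cause of this fall.

On these data alone, it remains open whether the fall belongs to the aromatic ring, the two fluorines or the carbamoyl link itself. A plain phenylcarbamoyl, a methylcarbamoyl or a longer chain such as butyl on the same oxygen would help to separate these.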